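Swapping a hydroxycyclohexyl amide for a fused bicyclic ether

A few compounds are considered here, and "the series" means these few. Any claim that something is new, unique, unknown or untested is made for them only; others in the source may bear on it.

The shared core carries two amide groups, and the compounds differ mainly in what hangs from one of them. Compound 1 `CNC(=O)c1cc(C(=O)NC2CC2)cc2c1O[C@H](CF)[C@H]2c1ccccc1` bears a cyclopropyl amide and a fluoromethyl side chain; in a physicochemical assay for solubility (on this read-out higher numbers stand for higher solubility and lower numbers for lower solubility), compound 1 gives 8 ug/mL. Compound 2 `CNC(=O)c1cc(C(=O)N[C@H]2CC[C@H](O)CC2)cc2c1OC[C@@]2(C)c1ccccc1` bears a 4-hydroxycyclohexyl amide and a methyl on the core. In this assay compound 2 gives >= 161 ug/mL, which is a limit of the assay rather than a number. Compound 3 `CNC(=O)c1cc(C(=O)N[C@H]2[C@@H]3COC[C@@H]32)cc2c1OC[C@H]2c1ccncc1` bears a pyridine and the same amide group that compound 4 will carry. In this assay compound 3 gives >= 184 ug/mL, again a limit rather than a number. Compound 2 therefore stands at a limit, as does one other value shown the limit of >= 161 ug/mL in this assay, at which 1 of the 3 values shown sits (the limit of >= 184 ug/mL in this assay, at which 1 of the 3 values shown sits), while compound 1 alone gives a plain, low number.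

Compound 4 `CNC(=O)c1cc(C(=O)N[C@H]2[C@@H]3COC[C@@H]32)cc2c1OC[C@@]2(C)c1ccccc1` keeps the core of compound 2 and changes only the amide substituent: a group of 6 heavy atoms (5 carbon, 1 oxygen; one three-membered non-aromatic ring of carbon only, one five-membered non-aromatic ring with 1 hetero atom) in place of a group of 7 heavy atoms (6 carbon, 1 oxygen; one six-membered non-aromatic ring of carbon only), on an amide-type nitrogen. Among the compounds with values here, no measured pair shows this change, so the size of the step is open. Because compound 2 sits at >= 161 ug/mL, any step can only be estimated as a fall or as none beyond the scatter. The expected step is an at least 2.0-fold lower number from compound 2 to compound 4 (0.30 log units; that floor lies within the scatter). Compound 4 is estimated at 80 ug/mL, within 20 ug/mL to 200 ug/mL, with a fair chance that only a limit is reported.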

Compound 4, solubility: >= 147 ug/mL
Compound 4: a limit, no number; the forecaster's own chance of this, stated with the estimate: 35%; at least 1.8-fold (0.26 log units) between middle value and limit.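

Compound 2 and compound 4 both give limits rather than plain numbers in this assay, and the size of the step between them cannot be read. The compounds shown leave open how the 4-hydroxycyclohexyl group and the fused group that replaces it compare on this read-out, since neither compound has a plain number.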